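Hydroxymethyl for methoxycarbonyl on the aryl of compound 3

The source may report more compounds than this note shows. Statements on the series, on what has been measured and on what is new or still open speak of the compounds shown alone.

Three ureas on a shared core have been measured in an assay on microsomes for inhibition of acyl-CoA:cholesterol acyltransferase (Oryctolagus cuniculus); a lower number here means a stronger inhibitor, a higher number a weaker inhibitor. Compound 1 `CC(C)c1cccc(C(C)C)c1NC(=O)NCC1(c2ccc(NCCO)cc2)CCCC1` gives 25 nM, compound 2 `COC(=O)c1cccc(C2(CNC(=O)Nc3c(C(C)C)cccc3C(C)C)CCCC2)c1` gives 34 nM, and compound 3 `COC(=O)c1ccc(C2(CNC(=O)Nc3c(C(C)C)cccc3C(C)C)CCCC2)cc1` gives 360 nM. Compound 3 stands at the highest number of the three: an 11-fold higher number from compound 2 to compound 3 (1.02 log units; beyond the scatter) and a 14-fold higher number from compound 1 to compound 3 (1.16 log units; beyond the scatter), whereas a 1.4-fold higher number from compound 1 to compound 2 (0.13 log units; within the scatter).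

Compound 4 `CC(C)c1cccc(C(C)C)c1NC(=O)NCC1(c2ccc(CO)cc2)CCCC1` differs from compound 3 in one place: hydroxymethyl in place of methoxycarbonyl on an aromatic carbon. For the measured compounds named here, the step that bears on this change is the one in which a group carrying a hydrogen-bond donor on an aromatic carbon gave way to methoxycarbonyl, with a strong rise in the number: a 14-fold higher number from compound 1 to compound 3 (1.16 log units; beyond the scatter). The step from compound 2 to compound 3 keeps methoxycarbonyl throughout and does not inform the present change. Compound 4 brings back a donor-bearing group, and a lower number is expected because a 14-fold higher number from compound 1 to compound 3 (1.16 log units; beyond the scatter) shows the donor-bearing analogue well below the ester; hydroxymethyl is smaller than (2-hydroxyethyl)amino, so only part of that gap is expected to close, a 3.6-fold lower number from compound 3 to compound 4 (0.56 log units; beyond the scatter). Compound 4 is estimated at 100 nM, with a range from 30 nM to 350 nM.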

Compound 4, half-maximal inhibitory concentration: 26 nM
Compound 4: the middle estimate sits 3.8-fold (0.59 log units) above what was measured, and the stated range ends above it.
By their numbers in this assay, from the lowest: compounds 1, 4 and 2 (each within the scatter of the next); then compound 3.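

In this assay, hydroxymethyl in place of methoxycarbonyl on this aromatic carbon, para to a large group, is a large step on its own (a 14-fold lower number from compound 3 to compound 4 (1.14 log units; beyond the scatter)), so the high number of compound 3 goes with the ester at this place and does not return with a group of only 2 heavy atoms. The (2-hydroxyethyl)amino group is not needed for a low number, as the two groups cannot be told apart here (a 1.0-fold higher number from compound 1 to compound 4 (0.02 log units; within the scatter)). The 4-(hydroxymethyl)phenyl and 3-(methoxycarbonyl)phenyl variants of the shared core also read alike (a 1.3-fold lower number from compound 2 to compound 4 (0.12 log units; within the scatter)).

As far as these compounds go, whether the hydroxyl hydrogen counts, or only the absence of methoxycarbonyl, stays open: a methoxymethyl or plain methyl group at this place would separate the two, and a carboxylic acid or aminomethyl group would extend the comparison. Nothing measured here accounts for the size of the step.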